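The source may report more compounds than this note shows. Statements on the series, on what has been measured and on what is new or still open speak of the compounds shown alone.

Measured in a functional assay on HEK293 cells for agonist activity at Free fatty acid receptor 1 (Homo sapiens), read by fluorescence and calcium flux, with a stated time of 10 min; a lower number here means that less compound is needed, a higher number that more compound is needed for the effect:

compound 1 `Cn1cncc1C(CC(=O)O)c1ccc(OCC2COc3ccc(Cl)cc3O2)cc1` — 3060 nM
compound 2 `O=C(O)CC(c1ccncc1)c1ccc(OCC2COc3ccc(Cl)cc3O2)cc1` — 1170 nM
compound 3 `CC#C[C@@H](CC(=O)O)c1ccc(OC[C@H]2COc3ccc(F)cc3O2)cc1` — 210 nM

Compound 3 gives the lowest number of the three; compound 2 stands nearest to it and compound 1 furthest, both gaps beyond the scatter. The next compound, compound 4 `CC#C[C@@H](CC(=O)O)c1ccc(OC[C@H]2COc3ccc(C(=O)N4CCOCC4)cc3O2)cc1`, differs from compound 3 in one place: (morpholin-4-yl)carbonyl in place of fluoro on an aromatic carbon. Among the compounds with values here, the only measured step, a 2.6-fold lower number from compound 1 to compound 2 (0.42 log units; beyond the scatter), concerns a change on the saturated chain carbon, not on the aromatic carbon touched here, so no measured step bears directly on this change. With nothing to point either way, the step is expected to stay within the scatter: a 1.2-fold higher number from compound 3 to compound 4 (0.08 log units; within the scatter). Compound 4 is therefore estimated at 250 nM, with a range from 80 nM to 800 nM.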

Compound 4, half-maximal effective concentration: > 50000 nM
Compound 4: no number, only a limit; the forecaster's own chance of this, stated with the estimate: 5%; middle value at least 200-fold (2.30 log units) from the limit.
By their numbers in this assay, from the lowest: compound 3; then compound 2; then compound 1. At a limit, above all of these: compound 4.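

The aromatic carbon that carries fluoro in compound 3 does not tolerate every group: (morpholin-4-yl)carbonyl in its place gives an at least 230-fold higher number from compound 3 to compound 4 (2.37 log units; beyond the scatter), the first step shown at this position and the larger of the two steps shown. Compound 4 gives only a limit, not a number: the limit of > 50000 nM in this assay, at which 1 of the 4 values shown sits. As far as these compounds go, the full size of the step therefore stays unknown.

From the compounds shown here alone, it remains open whether the carbonyl or the morpholine ring accounts for this step. A methoxy group or a primary carboxamide on the same carbon would help to separate the two.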